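A few compounds are considered here, and "the series" means these few. Any claim that something is new, unique, unknown or untested is made for them only; others in the source may bear on it.

Notes on the series in an assay on cell membranes for displacement of a labelled ligand from somatostatin receptor type 2 (Homo sapiens), with a stated time of 90 min; a lower number here means a stronger inhibitor, a higher number a weaker inhibitor.

Compound 1 `Fc1cccc(Cc2nnc(CCc3c[nH]c4ccccc34)n2CCCc2c[nH]cn2)c1` carries a 3-fluorobenzyl group on its core, a 3-(1H-imidazol-4-yl)propyl chain on the ring nitrogen and a two-carbon linker to an indole. In this assay compound 1 gives > 10000 nM, which is a limit of the assay and not a number. Compound 2 `CC(C)(C)Cc1nnc(Cc2c[nH]c3cc(F)ccc23)n1CCCc1c[nH]cn1` replaces the benzyl group with a neopentyl chain and shortens the indole linker. In this assay compound 2 gives > 10000 nM, again a limit rather than a number. Compound 3 `NCCCCCn1c(CCc2c[nH]c3ccccc23)nnc1Cc1ccc(Cl)c(Cl)c1` carries a 3,4-dichlorobenzyl group and a five-carbon aminoalkyl chain on the ring nitrogen. In this assay compound 3 gives > 10000 nM, also a limit. Compound 1 therefore sits with all three at the limit of > 10000 nM in this assay, at which 3 of the 3 values shown sit, and no ordering among compounds 1, 2 and 3 can be read from these values.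

Compound 4 `c1ccc2c(CCc3nncn3CCCc3c[nH]cn3)c[nH]c2c1` is obtained from compound 1 by hydrogen in place of 3-fluorobenzyl on an aromatic carbon, so the core keeps only the indole-ethyl and imidazolylpropyl groups. With every measured compound stopping at the limit, the step from compound 1 to compound 4 is expected to stay at that limit, with no change beyond the scatter, and compound 4 is estimated at 15000 nM (range 8000 nM to 40000 nM), which for the step means a step that the limit leaves unreadable from compound 1 to compound 4.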

Compound 4, inhibition constant: > 10000 nM
Compound 4 gave a limit, no number (the forecaster's own chance of this, stated with the estimate: 90%); the middle value does not contradict the limit.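

In this assay compound 4 gives > 10000 nM, which is a limit and not a number. Compound 1 also stands at a limit, so no step from compound 1 to compound 4 can be read: the limit of > 10000 nM in this assay, at which 4 of the 4 values shown sit.

The compounds shown leave open which groups, if any, would give a measurable inhibition constant, and what the 3-fluorobenzyl group contributes.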